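Phenyl for heptyl on the shared core

The source may report more compounds than this note shows. Statements on the series, on what has been measured and on what is new or still open speak of the compounds shown alone.

Compound 3 `CCCCCCCC1C=C(Cl)CCN1S(=O)(=O)c1ccc(C)cc1` carries a heptyl group on a saturated ring carbon of the shared core. In a functional assay on WiDr cells (Homo sapiens) for antiproliferative activity, read by sulforhodamine B assay, with a stated time of 48 h (on this read-out higher numbers stand for weaker inhibition of growth and lower numbers for stronger inhibition of growth), compound 3 gives 50000 nM, the higher of the two numbers in hand, though compound 1 `Cc1ccc(S(=O)(=O)N2CC[C@@H](Br)C[C@@H]2c2ccccc2)cc1` lies within the scatter of it with 36000 nM. Compound 2 `Cc1ccc(S(=O)(=O)N2CC=C(Cl)CC2)cc1` reaches only a limit of the assay in this assay, > 100000 nM (the limit of > 100000 nM in this assay, at which 1 of the 3 values shown sits). Among the measured compounds shown here, the single measured step, an at least 2.0-fold lower number from compound 2 to compound 3 (0.30 log units; that floor lies within the scatter), adds a chain and says little about swapping one group for another. Compound 4 `Cc1ccc(S(=O)(=O)N2CCC(Cl)=CC2c2ccccc2)cc1` differs from compound 3 by phenyl in place of heptyl on a saturated ring carbon. Compound 1 also bears a phenyl and gives 36000 nM, so compound 4 is expected to land near it. Compound 4 is therefore estimated at 35000 nM (range 12000 nM to 100000 nM) in this assay, a step of a 1.4-fold lower number from compound 3 to compound 4 (0.15 log units; within the scatter) expected to stay within the scatter.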

Compound 4, concentration for 50% growth inhibition: 18000 nM
For compound 4 the middle estimate is 1.9-fold (0.29 log units) above the measured one, and the stated range covers the measured number.
By their numbers in this assay, from the lowest: compounds 4, 1 and 3 (each within the scatter of the next, the first and the last beyond it). At a limit, above all of these: compound 2.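

In this assay, exchanging one group for another on this saturated ring carbon gives a 2.8-fold lower number from compound 3 to compound 4 (0.44 log units; beyond the scatter), so the identity of the group matters here, which the heptyl addition alone, with its floor within the scatter, could not show. Phenyl in place of hydrogen at the same carbon gives an at least 5.5-fold lower number from compound 2 to compound 4 (0.74 log units; beyond the scatter), a floor rather than a size. Compound 2 stands at a limit of the assay: the limit of > 100000 nM in this assay, at which 1 of the 4 values shown sits.

As far as these compounds go, only heptyl and phenyl are compared at this carbon, so it remains open how a shorter chain, a substituted phenyl or an amine would behave there.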